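This account rests on a few compounds, and the source may have more. Where it says the series, first, only, none or still open, it means among the compounds named here.

Among the compounds with values here, the three compounds measured so far share a dimethylurea attached to a benzylic nitrogen and differ in what else that nitrogen carries. Compound 1 `CCOC(=O)N1CCC(N(Cc2cc(Cl)ccc2O)C(=O)N(C)C)CC1` gives, in a functional assay on KB cells (Homo sapiens) for antiproliferative activity, read by MTT assay, with a stated time of 48 h (on this read-out lower numbers stand for stronger inhibition and higher numbers for weaker inhibition), a half-maximal inhibitory concentration of 25700 nM. Compound 2 `CN(C)C(=O)N(Cc1ccc(O)cc1)Cc1ccco1` gives 52100 nM in this assay, and compound 3 `CN(C)C(=O)N(Cc1ccco1)Cc1cc(Br)ccc1O` gives 32800 nM. Among these three numbers compound 1 stands lowest; the gap to compound 3 lies within the scatter of the measurement, whereas the gap to compound 2 lies beyond it, so only compound 2 can be said to give a clearly higher number.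

Compound 4 `CCOC(=O)N1CCC(N(Cc2cc(Br)ccc2O)C(=O)N(C)C)CC1` has not yet been measured. It differs from compound 1 in one place: bromo in place of chloro on an aromatic carbon. Within the data shown here, no measured pair isolates exactly this exchange. The nearest hint is that compound 3, which carries the bromo group on the same hydroxyphenyl pattern, sits within the scatter of compound 1. On that basis no step beyond the scatter is expected, and the step from compound 1 to compound 4 is estimated at a 1.1-fold lower number from compound 1 to compound 4 (0.03 log units; within the scatter). Compound 4 is expected to give about 24000 nM, with a plausible range from 11000 nM to 52000 nM.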

Compound 4, half-maximal inhibitory concentration: 24600 nM
The estimate for compound 4 lay 1.0-fold (0.01 log units) below the measured number; the range from low to high includes it.
By their numbers in this assay, from the lowest: compounds 4, 1, 3 and 2 (each within the scatter of the next, the first and the last beyond it).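

Within the data shown here, the exchange at this position can now be read directly for the first time, on the core of compound 1: in this assay the record shows a 1.0-fold lower number from compound 1 to compound 4 (0.02 log units; within the scatter) and so stays within the scatter. Para to the hydroxy group on this core, chloro and bromo therefore cannot be told apart by this read-out, which no earlier compound could show because none formed a pair differing only here. Nothing measured on either halogen accompanies the result, so the data offer no explanation for this match.

As far as these compounds go, whether a fluoro, methoxy or amino group at this place would leave the number equally unmoved remains open. Also open is whether chloro and bromo would match with a different group on the urea nitrogen, as compound 3 has no chloro partner among the compounds shown.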